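From Methyl to Benzyl Ester on an Inactive Scaffold

The compounds below may be only part of what the source reports. "The series", "measured", "known", "first", "only" and "open" are said of these compounds alone.

Compound 3 `C/C=C1/[C@H](O[C@@H]2O[C@H](CO)[C@@H](O)[C@H](O)[C@H]2O)OC=C(C(=O)OC)[C@H]1CC(=O)OC` sits at the edge of what this measurement can see. In a functional assay on SK-BR-3 cells (Homo sapiens) for antiproliferative activity, read by MTT assay, with a stated time of 72 h (on this read-out lower numbers stand for stronger inhibition and higher numbers for weaker inhibition), compound 3 gives > 15000 nM, which is a limit of the assay and not a number. Its two neighbours tell the same story. Compound 1 `C/C=C1/[C@H](O[C@@H]2O[C@H](CO)[C@@H](O)[C@H](O)[C@H]2O)OC=C(C(=O)O)[C@H]1CC(=O)OC` differs from compound 3 only by methyl in place of hydrogen on an oxygen next to a carbonyl group, and in this assay compound 1 gives > 20000 nM, again only a limit. The step that the two limits leave unreadable from compound 1 to compound 3 is therefore unreadable. Compound 2 `C/C=C1/[C@H](O[C@@H]2O[C@H](COC(C)=O)[C@@H](OC(C)=O)[C@H](OC(C)=O)[C@H]2OC(C)=O)OC=C(C(=O)OC)[C@H]1CC(=O)OCCC1CCCCC1` is altered at several places at once, and in this assay compound 2 gives > 15000 nM, once more a limit. Going by the values given here, all three values are limits, the limit of > 15000 nM in this assay, at which 2 of the 3 values shown sit, and (the limit of > 20000 nM in this assay, at which 1 of the 3 values shown sits), so no measured step has a readable size.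

Compound 4 `C/C=C1/[C@H](O[C@@H]2O[C@H](CO)[C@@H](O)[C@H](O)[C@H]2O)OC=C(C(=O)OC)[C@H]1CC(=O)OCc1ccccc1` differs from compound 3 by phenyl in place of hydrogen on a saturated chain carbon bound to an oxygen next to a carbonyl group. Among the compounds with values here, no measured step bears on this change, and nothing among the three compounds points to a move away from the limit, so the step from compound 3 to compound 4 is expected to be a step that the limit leaves unreadable from compound 3 to compound 4, within the scatter. Compound 4 is accordingly estimated at 20000 nM, in a range from 5000 nM to 80000 nM.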

Compound 4, half-maximal inhibitory concentration: > 15000 nM
Compound 4: a limit, no number; the forecaster's own chance of this, stated with the estimate: 75%; the middle value does not contradict the limit.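

In this assay compound 4 gives > 15000 nM, a limit of the assay and not a number. Compound 3 also stands at a limit, so the step between compound 3 and compound 4 cannot be read. The compounds shown leave open whether any change to the shared core yields a measurable value in this assay.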